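Ester to Acid on the Shared Core

A few compounds are considered here, and "the series" means these few. Any claim that something is new, unique, unknown or untested is made for them only; others in the source may bear on it.

Compound 1 `Cc1nc2c(OCc3ccccc3)cccn2c1C#N`: 4%
Compound 2 `Cc1nc2c(OCc3ccccc3)cccn2c1CS(C)(=O)=O`: 0%
Compound 3 `COC(=O)Cc1c(C)nc2c(OCc3ccccc3)cccn12`: 16%

In a functional assay on the whole organism (stomach) for inhibition, with Canis familiaris (Canis lupus familiaris) as the target, at a dose of 5 mg/kg by the intravenous route (a lower number here means a weaker effect, a higher number a stronger effect of the compound at the dose given), compound 1 gives 4% and compound 2 gives 0%, a pair whose gap is within the scatter, as a number 4 percentage points lower from compound 1 to compound 2 (within the scatter) shows. Compound 3 stands highest of the three in this assay with 16%; its nearest neighbour is compound 1, reached by a number 12 percentage points higher from compound 1 to compound 3 (beyond the scatter), and the furthest is compound 2, reached by a number 16 percentage points higher from compound 2 to compound 3 (beyond the scatter), both modest steps beyond the scatter.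

Compound 4 `Cc1nc2c(OCc3ccccc3)cccn2c1CC(=O)O` is the next compound to be measured. It differs from compound 3 by hydrogen in place of methyl on an oxygen next to a carbonyl group, that is, methoxycarbonyl to carboxy. The two measured steps that bear on this change both swap the group on the same saturated chain carbon, and both were modest in size. For the measured compounds named here, no measured pair swaps methyl for hydrogen on an oxygen, so the direction cannot be read off the data. The step of a number 6 percentage points lower from compound 3 to compound 4 (within the scatter) is therefore expected to be small, with a slight lean downward. Compound 4 is estimated at 10% in this assay, within a range from 0% to 28%.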

Compound 4, a percentage reported as inhibition, in the whole organism at one dose (the size of the read-out at that dose, not a potency): 24%
Beside the measured number, compound 4's estimate is 14 percentage points below it; low and high end bracket the measured number.
By their numbers in this assay, from the lowest: compounds 2 and 1 (each within the scatter of the next); then compounds 3 and 4 (each within the scatter of the next).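

In this assay, replacing methoxycarbonyl with carboxy gives a number 8 percentage points higher from compound 3 to compound 4 (within the scatter), so putting hydrogen in place of methyl on this oxygen does not separate the ester from the acid. The acid does separate from the other two groups, with a number 24 percentage points higher from compound 2 to compound 4 (beyond the scatter) and a number 20 percentage points higher from compound 1 to compound 4 (beyond the scatter), both modest steps; among these four compounds, the two with a carbonyl group on the chain both stand beyond the scatter from the nitrile and the methylsulfonyl compound, and none goes against this. Nothing available explains these differences.

As far as these compounds go, it remains open whether a primary amide or an amine on the same saturated chain carbon would give a similar read-out, and what a longer chain ending in carboxy would do. From the compounds shown here alone, a single-dose read-out shows only the size of the effect at that dose, so whether these compounds would give a stronger or weaker effect at other doses also remains open.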